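This account rests on a few compounds, and the source may have more. Where it says the series, first, only, none or still open, it means among the compounds named here.

Of the compounds shown here, three sharing one core have been tested in an assay for inhibition of histone acetyltransferase KAT2B (Homo sapiens), read by TR-FRET, with a stated time of 10 min, tested at 50 uM; on this read-out lower numbers stand for less inhibition and higher numbers for more inhibition at the one concentration tested (going by the name of the read-out). Compound 1 `COC(=O)CCN1C(=O)/C(=C/c2cc(OC)ccc2OC)SC1=S` gives 8% in this assay. Compound 2 `Cc1ccc(CN2C(=O)/C(=C3\SC(=S)N(CCCCC(=O)O)C3=O)c3ccccc32)cc1` gives 8%, and compound 3 `CCOc1ccccc1/C=C1\SC(=S)N(CCCCCC(=O)OC)C1=O` gives 9%. Compound 2 is level with compound 1 at the digits shown, and together they are the lowest of the three numbers; its nearest neighbour is compound 1, with no change at the digits shown, and its furthest is compound 3, whose number is only slightly higher, a gap within the usual scatter of this kind of measurement. All three numbers therefore describe weak inhibition at the single concentration tested, and none can be ranked against the others.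

Compound 4 `COC(=O)CCCCCN1C(=O)/C(=C2/C(=O)N(Cc3ccc(C)cc3)c3ccccc32)SC1=S` has not yet been measured. It differs from compound 2 in one place: (methoxycarbonyl)methyl in place of carboxy on a saturated chain carbon, four bonds along the chain from an amide-type nitrogen in a ring. Among the measured compounds shown here, no measured pair shows this exact change, so the expectation rests on the spread of the numbers already in hand. For the measured compounds named here, since every compound so far sits at the same low level, the step of a number 1 percentage points higher from compound 2 to compound 4 (within the scatter) is expected to be none beyond the scatter. Compound 4 is accordingly estimated to give 9%, within a range from 0% to 20%, because compound 3 gives 9% and compound 1 gives 8% with no sign of a trend.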

Compound 4, a percentage reported as inhibition, at one concentration (the size of the read-out at that concentration, not a potency): 8%
Compound 4: middle estimate off by 1 percentage points, on the high side; the measured number falls inside the stated range.
By their numbers in this assay, from the lowest: compounds 1, 2, 4 and 3 (each within the scatter of the next).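

Among the compounds shown here, for the first time in this set a single change can be read directly: in this assay the swap of carboxy for (methoxycarbonyl)methyl on a saturated chain carbon, four bonds along the chain from an amide-type nitrogen in a ring, brings no change at the digits printed from compound 2 to compound 4 (within the scatter) and so leaves the number at the same low level. The entering group has 0 hydrogen-bond donors where carboxy has 1, yet at this position the two chain ends cannot be told apart, although with both numbers this low the result says only that neither end gives more than weak inhibition at the one concentration tested. Nothing measured here explains this flat step.

Still open, from the compounds shown here alone, is whether a different group at this chain end, such as an amine or a primary amide, or a longer chain would move the number beyond the scatter. Also open, going by these compounds, is whether the same swap would read alike on the part of the molecule carried by compound 3, for which a carboxylic acid partner would be the direct comparison.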